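Capping a Ring Nitrogen With Methyl: Compound 4

The compounds below may be only part of what the source reports. "The series", "measured", "known", "first", "only" and "open" are said of these compounds alone.

Of the compounds shown here, three sharing one core have been measured in a functional assay on PC-3 cells (Homo sapiens) for cytotoxicity, read by MTT assay, with a stated time of 72 h; a lower number here means a stronger inhibitor, a higher number a weaker inhibitor. Compound 1 `Cc1cc(=O)n(-c2cccc(F)c2)nc1C(=O)Nc1ccc(Oc2ncnc3[nH]ccc23)cc1` gives 14600 nM, compound 2 `Cc1ccc(-n2nc(C(=O)Nc3ccc(Oc4ncnc5[nH]ccc45)cc3)c(C)cc2=O)cc1` gives 9610 nM, and compound 3 `Cc1ccc(-n2nc(C(=O)Nc3ccc(Oc4ncnc5[nH]ccc45)c(F)c3)c(C)cc2=O)cc1` gives 20400 nM. Compound 2 shows the lowest number of the three, yet the gap to compound 1 is small, a 1.5-fold lower number from compound 1 to compound 2 (0.18 log units; within the scatter), so the two cannot be ranked; the gap to compound 3, a 2.1-fold higher number from compound 2 to compound 3 (0.33 log units; beyond the scatter), is modest but beyond the scatter.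

Compound 4 `Cc1ccc(-n2nc(C(=O)Nc3ccc(Oc4ncnc5c4ccn5C)cc3)c(C)cc2=O)cc1` differs from compound 2 by a single change: methyl in place of hydrogen on an aromatic nitrogen. Among the compounds with values here, neither measured step touches this ring nitrogen, so no direct precedent exists; both measured steps involve other parts of the molecule and were small. On that basis the change from compound 2 to compound 4 is expected to give a step of about a 1.6-fold higher number from compound 2 to compound 4 (0.19 log units; within the scatter), toward a somewhat higher number, though it may fall within the scatter. Compound 4 is therefore estimated at 15000 nM in this assay, with a plausible range from 5000 nM to 45000 nM.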

Compound 4, half-maximal inhibitory concentration: > 60000 nM
Compound 4: only a limit was reported; the forecaster's own chance of this, stated with the estimate: 10%; at least 4.0-fold (0.60 log units) between middle value and limit.
By their numbers in this assay, from the lowest: compounds 2, 1 and 3 (each within the scatter of the next, the first and the last beyond it). At a limit, above all of these: compound 4.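

In this assay, methyl in place of hydrogen on an aromatic nitrogen of the five-membered ring gives an at least 6.2-fold higher number from compound 2 to compound 4 (0.79 log units; beyond the scatter), a larger step than either of the two earlier ones. For compound 4, the reading of > 60000 nM is a limit of the assay and not a number: the limit of > 60000 nM in this assay, at which 1 of the 4 values shown sits. Among the places changed so far, this ring nitrogen is thus the one where a single added carbon moves the number most, and only a lower bound on that step is known.

The compounds shown cannot separate the loss of the hydrogen from the arrival of the methyl. Going by these compounds, an ethyl group or a longer chain ending in an amine on this nitrogen would show whether any group is tolerated there, and whether the same step holds with the 3-fluorophenyl of compound 1 remains open.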